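Aryl swaps on the imine carbon, cytotoxicity notes

The source may report more compounds than this note shows. Statements on the series, on what has been measured and on what is new or still open speak of the compounds shown alone.

Measured in a functional assay on HeLa cells (Homo sapiens) for cytotoxicity, read by MTT assay, with a stated time of 48 h, tested at 12.5 uM; on this read-out lower numbers stand for a weaker effect and higher numbers for a stronger effect at the one concentration tested:
compound 1 `CSc1ccc(/C=N/n2c(Cc3ccc(S(C)(=O)=O)cc3)n[nH]c2=S)cc1`: 27.9%
compound 2 `CS(=O)(=O)c1ccc(Cc2n[nH]c(=S)n2/N=C/c2c(F)cccc2Cl)cc1`: 49.8%
compound 3 `CS(=O)(=O)c1ccc(Cc2n[nH]c(=S)n2/N=C/c2cccs2)cc1`: 28.7%

Compound 1 gives the lowest of the three numbers. Compound 3 lies within the scatter of it, while compound 2 sits well above it, a number 21.9 percentage points higher from compound 1 to compound 2 (beyond the scatter). Going on to the thiophene analogue brings the number back to the level of compound 1, a number 21.1 percentage points lower from compound 2 to compound 3 (beyond the scatter). Among these three, only the 2-chloro-6-fluorophenyl case moves the read-out beyond the scatter.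

Compound 4 `CS(=O)(=O)c1ccc(Cc2n[nH]c(=S)n2/N=C/c2ccc(-c3ccccc3)cc2)cc1` is not yet measured. It differs from compound 1 in one place: phenyl in place of methylsulfanyl on an aromatic carbon. Going by the values given here, no measured step alters the methylsulfanyl group itself; the steps all replace the whole aryl group on the carbon with a double bond to nitrogen, so they serve only as a loose guide. Among the compounds with values here, exchanging 4-(methylsulfanyl)phenyl for thiophen-2-yl left the number unchanged, a number 0.8 percentage points higher from compound 1 to compound 3 (within the scatter), and the one sizeable step came from a differently substituted phenyl. With a phenyl entering where methylsulfanyl leaves, a small step is expected in this assay, in either direction and most likely within the scatter. Compound 4 is therefore estimated at 32%, with a range from 18% to 50%, which would mean an expected a number 4.1 percentage points higher from compound 1 to compound 4 (within the scatter).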

Compound 4, a percentage reported as activity, at one concentration (the size of the read-out at that concentration, not a potency): 30.4%
Compound 4: middle estimate off by 1.6 percentage points, on the high side; low and high end bracket the measured number.
By their numbers in this assay, from the lowest: compounds 1, 3 and 4 (each within the scatter of the next); then compound 2.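

In this assay, going by these compounds alone, this is the first step that leaves the aromatic ring on the carbon with a double bond to nitrogen in place and alters only its substituent, and it gives a number 2.5 percentage points higher from compound 1 to compound 4 (within the scatter) as the result of that single change. Methylsulfanyl, with 2 heavy atoms and no ring, gives way to phenyl, with 6 heavy atoms and a six-membered aromatic ring, yet the read-out stays within the scatter, so at this place para to a large group, this difference in size and ring count does not register in the number. No measured property accompanies this result, and the flat step remains without an explanation.

On these data alone, whether an amine or a carboxylic acid at this same place would move the number beyond the scatter stays open, since both groups exchanged here are uncharged. Also open is whether the chloro or the fluoro substituent alone would account for compound 2 at 49.8%, as no compound shown carries just one of the two.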